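Swapping the Aryl Group for Cyclopropyl on the Ring Amide

The source may report more compounds than this note shows. Statements on the series, on what has been measured and on what is new or still open speak of the compounds shown alone.

Compound 1 `COc1ncc(-c2ccc3c(c2)N(c2ccc(C)cc2)C(=O)CO3)cc1NS(=O)(=O)c1ccc(F)cc1` carries a 4-methylphenyl on the amide-type nitrogen in a ring of the shared core. In a functional assay on A-375 cells (Homo sapiens) for antiproliferative activity, read by MTT assay, with a stated time of 72 h (a higher number here means a weaker inhibitor, a lower number a stronger inhibitor), compound 1 gives 12900 nM, the lowest of the two numbers shown. Compound 3 `Cc1ccc(N2C(=O)COc3ccc(-c4cnc(Cl)c(NS(=O)(=O)c5ccc(F)cc5)c4)cc32)cc1` gives 38900 nM in this assay, and the step of a 3.0-fold higher number from compound 1 to compound 3 (0.48 log units; beyond the scatter) sits on an aromatic carbon. Compound 2 `COc1cccc(N2C(=O)COc3ccc(-c4cnc(Cl)c(NS(=O)(=O)c5ccc(F)cc5)c4)cc32)c1` reaches only a limit, > 40000 nM in this assay (the limit of > 40000 nM in this assay, at which 1 of the 3 values shown sits). The step of an at least 1.0-fold lower number from compound 2 to compound 3 (0.01 log units; that floor lies within the scatter) is the only one on the amide-type nitrogen in a ring, and it rests on a limit, so it tells little. Compound 4 `COc1ncc(-c2ccc3c(c2)N(C2CC2)C(=O)CO3)cc1NS(=O)(=O)c1ccc(F)cc1` differs from compound 1 by cyclopropyl in place of 4-methylphenyl on an amide-type nitrogen in a ring. Going by the values given here, no measured step here trades an aromatic ring for cyclopropyl, so the expected step is small, a 1.6-fold higher number from compound 1 to compound 4 (0.19 log units; within the scatter). Compound 4 is estimated at 20000 nM, within 6000 nM to 60000 nM.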

Compound 4, half-maximal inhibitory concentration: 23900 nM
Estimate against measurement, compound 4: 1.2-fold (0.08 log units) below; measured number inside the range.
By their numbers in this assay, from the lowest: compounds 1, 4 and 3 (each within the scatter of the next, the first and the last beyond it). At a limit, above all of these: compound 2.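

Going by these compounds alone, on the amide-type nitrogen in a ring, the only earlier step rested on a limit, so this is the first step there that can be read as a size. In this assay, cyclopropyl in place of 4-methylphenyl gives a 1.9-fold higher number from compound 1 to compound 4 (0.27 log units; within the scatter), so compounds 1 and 4 cannot be told apart, even though 3 heavy atoms stand where 7 stood and the aromatic ring is gone. No measurement shown here bears on why. Going by these compounds, how a longer chain, such as n-butyl, or a group carrying an amine or a carboxylic acid would behave on this nitrogen remains open.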